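Ethyl for ethylamino on the shared core, compound 2 to 4

The compounds below may be only part of what the source reports. "The series", "measured", "known", "first", "only" and "open" are said of these compounds alone.

Notes on the series. In an assay on HEK293 cells for positive allosteric modulation of metabotropic glutamate receptor 5 (Rattus norvegicus) (on this read-out lower numbers stand for an effect already at smaller amounts and higher numbers for an effect only at larger amounts of compound), compound 1 `CCNc1ncc(C#Cc2cccc(C)c2)cn1` is recorded as "not active" (no number reported), with no number attached. Compound 2 `CCNc1ncc(C#Cc2ccccc2)cn1` is recorded the same way, as "not active" (no number reported) in this assay, again without a number. Only compound 3 `CNc1ncc(C#Cc2cccc(C)c2)cn1` carries a figure: in this assay compound 3 gives 21100 nM. Going by the values given here, compound 2 therefore stands among the entries with no single number, alongside compound 1, and no step between measured compounds can be written for it.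

The unmeasured compound 4 `CCc1ncc(C#Cc2ccccc2)cn1` differs from compound 2 as follows: ethyl in place of ethylamino on an aromatic carbon. This is ethyl in place of ethylamino on an aromatic carbon.

No measured step resembles this change, so its size in this assay cannot be read off anything shown. The shared core has given one weak figure, that of compound 3, and two entries without a number; the step from compound 2 to compound 4 is expected to leave the compound in that same weak region, with no clear direction beyond the scatter, and a good chance that again no number is returned. For compound 4 the estimate in this assay is 30000 nM, within 8000 nM to 100000 nM.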

Compound 4, half-maximal effective concentration: "not active" (no number reported)
Compound 4 has no reported number here; no gap can be computed for the estimate.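

In this assay compound 2 gives "not active" (no number reported) and compound 4 gives "not active" (no number reported) and so no step can be read between them. The compounds shown leave open whether ethyl in place of ethylamino changes the response on the shared core at all. Nothing shown bears on this result.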